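A few compounds are considered here, and "the series" means these few. Any claim that something is new, unique, unknown or untested is made for them only; others in the source may bear on it.

Measured in an ADME assay on HeLa cells (Homo sapiens) for cytotoxicity, read by MTT assay, with a stated time of 2 days; a higher number here means that more compound is tolerated, a lower number that less compound is tolerated:
- Compound 1 `CCOC(=O)c1sc2cc(Oc3ccnc(C(=O)NC)c3)ccc2c1C`: > 100000 nM, a limit
- Compound 2 `CCCOC(=O)c1sc2cc(Oc3ccnc(C(=O)NC)c3)ccc2c1C`: 57100 nM
- Compound 3 `CNC(=O)c1cc(Oc2ccc3c(C)c(C(=O)O)sc3c2)ccn1`: > 100000 nM, a limit

Compound 3 has no number in this assay, only a limit. It stands with the limit of > 100000 nM in this assay, at which 2 of the 3 values shown sit. Compound 4 `CNC(=O)c1cc(Oc2ccc3c(C)c(C(=O)N(C)C)sc3c2)ccn1` differs from it by one change: dimethylamino in place of hydroxy on a carbonyl carbon. In words, dimethylamino replaces hydroxy on a carbonyl carbon.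

The nearest measured evidence comes from changes around a carbonyl group, although none of them puts dimethylamino there. Replacing propyl with hydrogen on the oxygen gives an at least 1.7-fold higher number from compound 2 to compound 3 (0.24 log units; that floor lies within the scatter). Replacing ethyl with hydrogen gives a step that the two limits leave unreadable from compound 1 to compound 3. Lengthening the ethyl chain, with methyl in place of hydrogen, gives an at least 1.7-fold lower number from compound 1 to compound 2 (0.24 log units; that floor lies within the scatter). None of these steps can be read as lying beyond the scatter. Among the measured compounds shown here, compound 2, at 57100 nM, is the only compound here with a number.

No step beyond the scatter is therefore expected, and any small shift would more likely be towards a lower number. The expected size is an at least 1.1-fold lower number from compound 3 to compound 4 (0.04 log units; that floor lies within the scatter). For compound 4 the estimated value is 90000 nM, with an expected range of 35000 nM to 200000 nM.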

Compound 4, half-maximal cytotoxic concentration: 44400 nM
The estimate for compound 4 lay 2.0-fold (0.31 log units) above the measured number; the range from low to high includes it.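

Dimethylamino on this carbonyl carbon gives the first steps at this position that can be read as beyond the scatter: an at least 2.2-fold lower number from compound 3 to compound 4 (0.35 log units; beyond the scatter), and an at least 2.2-fold lower number from compound 1 to compound 4 (0.35 log units; beyond the scatter). Compound 1 and compound 3 each stand only at a limit, so both steps give a floor and not a full size: the limit of > 100000 nM in this assay, at which 2 of the 4 values shown sit. Against the propoxy group the change stays within the scatter, a 1.3-fold lower number from compound 2 to compound 4 (0.11 log units; within the scatter), so in this assay dimethylamino and propoxy on this carbon cannot be told apart, while hydroxy and ethoxy are now separated from dimethylamino.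

How far the number would fall with other groups on this carbonyl carbon stays open, since a smaller amine such as methylamino, a cyclic amine such as pyrrolidine or morpholine, and a longer ester chain such as butoxy are not among the compounds shown. Also open, going by these compounds, is whether the lower number follows from the nitrogen itself or from the larger group, as the three steps to compound 4 change both at once and none separates them.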